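This account rests on a few compounds, and the source may have more. Where it says the series, first, only, none or still open, it means among the compounds named here.

Of the compounds shown here, two sharing one core have been measured in a functional assay on CHO-K1 cells for agonist activity at relaxin-3 receptor 1 (Homo sapiens), read by TR-FRET and cAMP accumulation, with a stated time of 1.5 h; a higher number here means that more compound is needed for the effect, a lower number that less compound is needed. Compound 1 `COc1cc(C)c2[nH]cc(/C=N/NC(=N)Nc3ccc(Cl)cc3)c2c1` carries a 4-chlorophenyl on an amine nitrogen, and in this assay compound 1 gives 3120 nM. Compound 2 `COc1cc(C)c2[nH]cc(/C=N/NC(=N)NCc3ccc(Cl)cc3)c2c1` carries a 4-chlorobenzyl in the same position, and in this assay compound 2 gives 3950 nM. Among the measured compounds shown here, the single step between them, a 1.3-fold higher number from compound 1 to compound 2 (0.10 log units; within the scatter), shows that inserting one saturated carbon between the ring and the nitrogen left the number essentially unchanged. Compound 2 thus sits at the higher of the two measured numbers, but its separation from compound 1 is too small to call a difference.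

Compound 3 `COc1cc(C)c2[nH]cc(/C=N/NC(=N)NCCCc3ccc(Cl)cc3)c2c1` extends the chain once more: 2-(4-chlorophenyl)ethyl in place of 4-chlorophenyl on a saturated chain carbon bound to an amine nitrogen. For the measured compounds named here, the only measured step that bears on this change is a 1.3-fold higher number from compound 1 to compound 2 (0.10 log units; within the scatter), which was within the scatter, so a further lengthening of the same chain is expected to give at most a small step in this assay, if any, with a slight lean toward a higher number. On that basis compound 3 is estimated at 4800 nM, within a range from 2000 nM to 11000 nM, which corresponds to an expected step of a 1.2-fold higher number from compound 2 to compound 3 (0.08 log units; within the scatter).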

Compound 3, half-maximal effective concentration: 1660 nM
Compound 3: the middle estimate sits 2.9-fold (0.46 log units) above what was measured; measured number outside the range, below it.
By their numbers in this assay, from the lowest: compounds 3, 1 and 2 (each within the scatter of the next, the first and the last beyond it).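

In this assay the longer chain does move the number: a 2.4-fold lower number from compound 2 to compound 3 (0.38 log units; beyond the scatter), a modest step, but the first in this series to lie beyond the scatter, so the group placed on a saturated chain carbon bound to an amine nitrogen can matter here. The earlier change gave no such sign, with a 1.3-fold higher number from compound 1 to compound 2 (0.10 log units; within the scatter), so chain length does not act evenly across these three compounds, and compound 2 goes against any simple rule that each lengthening lowers the number. Nothing available explains why 2-(4-chlorophenyl)ethyl gives a lower number than 4-chlorophenyl at this place.

On these data alone, whether a still longer chain would lower the number further or turn the step back remains open, since one step beyond the scatter does not establish a trend. Also open, as far as these compounds go, is whether the chlorine matters to this result, which a plain phenyl or a methoxy group in its place on the same chain would help to show.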